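Moving Two Chlorines Around the Benzyl Ring

The compounds below may be only part of what the source reports. "The series", "measured", "known", "first", "only" and "open" are said of these compounds alone.

Measured so far in a functional assay on MGC-803 cells (Homo sapiens) for inhibition, read by MTT assay, with a stated time of 48 h; a lower number here means a stronger inhibitor, a higher number a weaker inhibitor:
Compound 1 `Cc1ccc(NC(=S)NC(=O)c2ccc(OCc3ccc(Cl)cc3Cl)cc2)cc1-c1nc2ccccc2[nH]1` gives 3450 nM
Compound 2 `O=C(NC(=S)Nc1ccc(Cl)c(-c2nc3ccccc3[nH]2)c1)c1ccc(OCc2ccc(C(F)(F)F)cc2)cc1` gives 5330 nM
Compound 3 `O=C(NC(=S)Nc1ccc(Cl)c(-c2nc3ccccc3[nH]2)c1)c1ccc(OCc2ccc(Cl)c(Cl)c2)cc1` gives 5170 nM

All three share a core and differ only in the substituent carried on the benzyl ether and in one group on the other aryl ring. Compound 3 stands second highest of the three numbers in this assay; its nearest neighbour is compound 2 and its furthest is compound 1, and both gaps lie within the scatter, so no order among them can be claimed.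

The next compound, compound 4 `O=C(NC(=S)Nc1ccc(Cl)c(-c2nc3ccccc3[nH]2)c1)c1ccc(OCc2ccc(Cl)cc2Cl)cc1`, differs from compound 3 only in the arrangement of the two chlorines: 2,4-dichlorophenyl in place of 3,4-dichlorophenyl on a saturated chain carbon bound to an oxygen on an aromatic ring. Among the measured compounds shown here, one measured step bears on this place, the change of the benzyl substituent pattern from compound 2 to compound 3, which gave a 1.0-fold lower number from compound 2 to compound 3 (0.01 log units; within the scatter). Compound 1, which already carries the 2,4-dichlorophenyl group on a differently substituted core, shows a value within the scatter of compound 3. On this basis no step beyond the scatter is expected in this assay, in either direction.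

Compound 4 is therefore estimated to give 4500 nM, with a range from 2000 nM to 10000 nM. The expected step is a 1.1-fold lower number from compound 3 to compound 4 (0.06 log units; within the scatter).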

Compound 4, half-maximal inhibitory concentration: 3030 nM
Estimate against measurement, compound 4: 1.5-fold (0.17 log units) above, within the range that was stated.
By their numbers in this assay, from the lowest: compounds 4, 1, 3 and 2 (each within the scatter of the next).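

In this assay, among the compounds shown here, the first direct comparison of the two chlorine arrangements on the benzyl ring gives a 1.7-fold lower number from compound 3 to compound 4 (0.23 log units; within the scatter), and the change from the 4-(trifluoromethyl)phenyl group to the 2,4-dichlorophenyl group gives a 1.8-fold lower number from compound 2 to compound 4 (0.25 log units; within the scatter), so the three groups tried at this position cannot be put in any order. With the 2,4-dichlorophenyl group now held constant, the pair that differs only in chloro in place of methyl on an aromatic carbon gives a 1.1-fold lower number from compound 1 to compound 4 (0.06 log units; within the scatter), so this change on the shared core cannot be told apart from no change in this assay. No measurement is available that would account for any of these numbers.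

The compounds shown all carry chlorine or trifluoromethyl on the benzyl ring, so they leave open whether an unsubstituted benzyl group, or a benzyl ring bearing a methoxy group or an amine, would produce a step beyond the scatter. Going by these compounds, whether a carboxylic acid on that ring, or a longer chain between the ether oxygen and the ring, would do so also remains open.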